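The source may report more compounds than this note shows. Statements on the series, on what has been measured and on what is new or still open speak of the compounds shown alone.

Compound 1 `O=C1/C(=C\c2c(Cl)cccc2Cl)c2ccccc2N1c1c(Cl)cccc1Cl` and compound 2 `O=C1/C(=C\c2ccc(O)cc2)c2ccccc2N1c1c(Cl)cccc1Cl` share one core and differ only in the aryl group on the exocyclic double bond. Among the compounds with values here, in a functional assay on HuTu80 cells (Homo sapiens) for cytotoxicity, read by MTT assay, with a stated time of 72 h (on this read-out lower numbers stand for an effect already at smaller amounts and higher numbers for an effect only at larger amounts of compound), compound 1 gives 100 ug/mL, while compound 2 gives 25 ug/mL, the lowest of the two numbers so far; the step of a 4.0-fold lower number from compound 1 to compound 2 (0.60 log units; beyond the scatter) is the only measured one. Compound 3 `O=C1/C(=C\c2ccc(F)cc2)c2ccccc2N1c1c(Cl)cccc1Cl` carries the change (fluoro in place of hydroxy on an aromatic carbon). Within the data shown here, no measured step bears directly on it, and the hydroxy loss can only be guessed from compound 2 and its value 25 ug/mL. A small rise in number is expected, roughly a 1.6-fold higher number from compound 2 to compound 3 (0.20 log units; within the scatter), so compound 3 is estimated at 40 ug/mL, between 15 ug/mL and 100 ug/mL.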

Compound 3, concentration for half-maximal effect: 8 ug/mL
Compound 3: middle estimate off by 5.0-fold (0.70 log units), on the high side, and the stated range ends above it.
By their numbers in this assay, from the lowest: compound 3; then compound 2; then compound 1.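

Fluoro in place of hydroxy on this aromatic carbon lowers the number further (a 3.1-fold lower number from compound 2 to compound 3 (0.49 log units; beyond the scatter)), so a hydrogen-bond donor there is not required for the effect in this assay. Within the data shown here, the 4-fluorophenyl group in place of 2,6-dichlorophenyl gives the largest step so far (a 13-fold lower number from compound 1 to compound 3 (1.10 log units; beyond the scatter)). Nothing at hand explains either step.

Going by these compounds, whether other groups on this carbon, such as an amine, a methoxy group or a carboxylic acid, would give lower or higher numbers stays open. So does the contribution of the dichlorinated aryl group on the shared core, which all three compounds carry.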